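The source may report more compounds than this note shows. Statements on the series, on what has been measured and on what is new or still open speak of the compounds shown alone.

Among the measured compounds shown here, in an ADME assay on L1210 cells (Mus musculus) for cytotoxicity, with a stated time of 48 h (on this read-out lower numbers stand for stronger inhibition and higher numbers for weaker inhibition), compound 1 `C=C1[C@H](C)CCC[C@]1(C)CC/C(C)=C/CC1=C(O)C(=O)C=C(N[C@H](CO)C(=O)O)C1=O` gives 2.6 ug/mL, the only true number so far. Compound 2 `CC1=CCC[C@](C)(CC/C(C)=C/CC2=C(O)C(=O)C=C(N[C@H](CO)C(=O)O)C2=O)[C@@H]1C` reads > 10 ug/mL, which is a limit of the assay and not a number. The structural change under study leads to compound 3 `C=C1[C@H](C)CCC[C@]1(C)CC/C(C)=C/CC1=C(O)C(=O)C=C(N[C@H](C(=O)O)C(C)C)C1=O`: 1-carboxy-2-methylpropyl in place of 1-carboxy-2-hydroxyethyl on an amine nitrogen. For the measured compounds named here, the one measured step, an at least 3.8-fold higher number from compound 1 to compound 2 (0.58 log units; beyond the scatter), lies elsewhere, in the ring group on a saturated chain carbon, so it bears only indirectly on this change. It shows that this assay can respond to a change in this series, but it gives no size or direction for a change on the amine nitrogen. The expectation therefore starts from compound 1 at 2.6 ug/mL, with no step beyond the scatter expected and a wide margin kept. The estimated step is a 1.2-fold higher number from compound 1 to compound 3 (0.06 log units; within the scatter). Compound 3 is estimated at 3 ug/mL, with an expected range from 1 ug/mL to 9 ug/mL.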

Compound 3, half-maximal inhibitory concentration: 4.4 ug/mL
The estimate for compound 3 lay 1.5-fold (0.17 log units) below the measured number; low and high end bracket the measured number.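

In this assay, the exchange on the amine nitrogen now has a measured size: 1-carboxy-2-methylpropyl in place of 1-carboxy-2-hydroxyethyl gives a 1.7-fold higher number from compound 1 to compound 3 (0.23 log units; within the scatter). In this one pair, the hydroxyl of the leaving group is therefore not required for a reading in this range, and the position accepts a branched carbon end in its place without a step beyond the scatter. The values shown offer no explanation for this small step.

From the compounds shown here alone, whether the carboxylic acid on this group is needed remains open, as does the outcome with a methyl ester, a primary amide or a basic amine in its place. Also open, going by these compounds, is how a longer chain or a phenyl ring on the same carbon would read, and whether this exchange behaves the same way on the ring group of compound 2.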